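The source may hold more compounds than are shown below. What is called first, only, known or untested is meant among the compounds shown, and "the series" means these compounds.

Three compounds measured in a functional assay on SW-620 cells (Homo sapiens) for inhibition, read by sulforhodamine B assay, with a stated time of 48 h; on this read-out lower numbers stand for stronger inhibition of growth and higher numbers for weaker inhibition of growth:
compound 1, `COc1cc(-c2nn(-c3cccc(NC(=O)c4cccc(C(F)(F)F)c4)c3)cc2-c2ccncc2)ccc1Cl`, gives 2310 nM;
compound 2, `COc1cc(-c2nn(-c3cccc(NC(=O)Nc4cccc(C(F)(F)F)c4)c3)cc2-c2ccncc2)ccc1Cl`, gives 1230 nM;
compound 3, `COc1cc(-c2nn(-c3cccc(NC(=O)Nc4ccc(Cl)c(C(F)(F)F)c4)c3)cc2-c2ccncc2)ccc1Cl`, gives 1290 nM.

Compound 3 stands second highest of the three numbers, yet every gap is within the scatter: a 1.0-fold higher number from compound 2 to compound 3 (0.02 log units; within the scatter) and a 1.8-fold lower number from compound 1 to compound 3 (0.25 log units; within the scatter). Compound 4, `O=C(Nc1cccc(-n2cc(-c3ccncc3)c(-c3ccc(Cl)c(O)c3)n2)c1)Nc1ccc(Cl)c(C(F)(F)F)c1`, differs from compound 3 by a single change: hydrogen in place of methyl on an oxygen on an aromatic ring. Among the compounds with values here, none of the measured steps touches this oxygen; all three concern the carbonyl side of the shared core, and the only single change among them, a 1.0-fold higher number from compound 2 to compound 3 (0.02 log units; within the scatter), made no difference beyond the scatter. With nothing in these numbers speaking for a shift, compound 4 is expected to stay close to compound 3, a step of a 1.0-fold higher number from compound 3 to compound 4 (0.00 log units; within the scatter), so compound 4 is estimated at 1300 nM, between 500 nM and 3400 nM.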

Compound 4, concentration for 50% growth inhibition: 1150 nM
For compound 4 the middle estimate is 1.1-fold (0.05 log units) above the measured one; measured number inside the range.
By their numbers in this assay, from the lowest: compounds 4, 2, 3 and 1 (each within the scatter of the next).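

Within the data shown here, the step at this oxygen reads a 1.1-fold lower number from compound 3 to compound 4 (0.05 log units; within the scatter) in this assay, the first comparison to touch this part of the molecule. Going from methoxy to hydroxy on the 4-chloro-3-methoxyphenyl ring therefore makes no difference beyond the scatter, so the methyl is not needed to keep this level of growth inhibition in this pair. Nothing available offers a reason for this result. Still open, as far as these compounds go, is whether an ethoxy group or an amine at this place would shift the number. Also open, from the compounds shown here alone, is whether the same change behaves alike on compound 1, which has an amide in place of the urea.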